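The source may hold more compounds than are shown below. What is called first, only, known or untested is meant among the compounds shown, and "the series" means these compounds.

Compound 1 `O=C(CCc1ccc(C(F)(F)F)cc1)Nc1ccc2nc(N3CC4CC3CN4)ccc2c1`: 210 nM
Compound 2 `Nc1ccc2cc(NC(=O)CCc3ccc(C(F)(F)F)cc3)ccc2n1`: 240 nM
Compound 3 `O=C(CCc1ccc(C(F)(F)F)cc1)Nc1ccc2nc(N3CCCCCC3)ccc2c1`: 36 nM

All three compounds share a core and were tested in an assay on isolated protein for displacement of a labelled ligand from melanin-concentrating hormone receptor 1 (Homo sapiens); a lower number here means a stronger inhibitor, a higher number a weaker inhibitor. Compound 3 gives the lowest number of the three, at 36 nM, and both of its steps to the others lie beyond the scatter: a 5.8-fold lower number from compound 1 to compound 3 (0.77 log units; beyond the scatter) and a 6.7-fold lower number from compound 2 to compound 3 (0.82 log units; beyond the scatter). Compound 1 and compound 2 sit close together, with a 1.1-fold higher number from compound 1 to compound 2 (0.06 log units; within the scatter).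

Compound 4 `O=C(CCc1ccc(C(F)(F)F)cc1)Nc1ccc2nc(N3CCCCC3)ccc2c1` has not yet been measured. It differs from compound 3 by a single change: piperidin-1-yl in place of azepan-1-yl on an aromatic carbon. The ring on that aromatic carbon is kept, but it shrinks by one carbon.

The measured steps bear on this only loosely. Both steps that reach compound 3 replace quite different groups with azepan-1-yl, and each lowers the number by a modest amount. Neither step compares two plain saturated rings of neighbouring size, so the direction of the change to compound 4 cannot be read directly from them. A ring that keeps its single nitrogen and loses one carbon is expected to behave much like compound 3, so the step from compound 3 to compound 4 is estimated to be small, probably within the scatter, if anything a slight rise: a 1.5-fold higher number from compound 3 to compound 4 (0.18 log units; within the scatter). Compound 4 is therefore expected to give about 55 nM in this assay, somewhere between 20 nM and 150 nM.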

Compound 4, half-maximal inhibitory concentration: 12 nM
The estimate for compound 4 lay 4.6-fold (0.66 log units) above the measured number, and the stated range ends above it.
By their numbers in this assay, from the lowest: compound 4; then compound 3; then compounds 1 and 2 (each within the scatter of the next).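

Among these compounds, at this position, next to the ring nitrogen, the earlier compounds compared only very different groups, whereas this pair isolates ring size in this assay. Going from the seven-membered azepan-1-yl to the six-membered piperidin-1-yl gives a 3.0-fold lower number from compound 3 to compound 4 (0.48 log units; beyond the scatter) even though the hydrogen-bond donor and acceptor counts and the net charge stay the same, so the number responds to ring size alone here. Piperidin-1-yl also gives steps classed as large, with a 20-fold lower number from compound 2 to compound 4 (1.30 log units; beyond the scatter) and with an 18-fold lower number from compound 1 to compound 4 (1.24 log units; beyond the scatter) in the same assay, making compound 4 the lowest of the four by steps beyond the scatter to each of the others. Nothing available here explains why the six-membered ring gives the lower number.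

The compounds shown leave open whether a still smaller ring, pyrrolidin-1-yl, would lower the number further or raise it again, so the six-membered ring cannot yet be called the best size. They also leave open how a six-membered ring holding a second hetero atom, such as morpholin-4-yl or piperazin-1-yl, would compare with piperidin-1-yl at this position.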